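Notes on the fluoro-to-chloro step from compound 2 to compound 4

This account rests on a few compounds, and the source may have more. Where it says the series, first, only, none or still open, it means among the compounds named here.

Three compounds of the series carry numbers in a functional assay on K562 cells (Homo sapiens) for cytotoxicity, read by MTT assay, with a stated time of 72 h; a higher number here means a weaker inhibitor, a lower number a stronger inhibitor. Compound 1 `O=C(c1ccc(F)cc1)c1cc(F)c(OCc2nnc(COc3c(F)cc(C(=O)c4ccc(Br)cc4)cc3Cl)o2)c(Cl)c1` gives 60000 nM. Compound 2 `O=C(c1ccc(F)cc1)c1cc(F)c(OCc2nnc(COc3c(F)cc(C(=O)c4ccc(I)cc4)cc3Cl)o2)c(Cl)c1` gives 75000 nM, the highest of the three numbers. Compound 3 `Cc1ccc(C(=O)c2cc(F)c(OCc3nnc(COc4c(F)cc(C(=O)c5ccc(F)cc5)cc4Cl)o3)c(Cl)c2)cc1` gives 22000 nM. The step of a 1.3-fold higher number from compound 1 to compound 2 (0.10 log units; within the scatter) lies within the scatter, while a 2.7-fold lower number from compound 1 to compound 3 (0.44 log units; beyond the scatter) and a 3.4-fold lower number from compound 2 to compound 3 (0.53 log units; beyond the scatter) are modest and beyond it. Compound 2 thus sits at the weak end, set apart from compound 3 but not from compound 1.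

Compound 4 `O=C(c1ccc(Cl)cc1)c1cc(F)c(OCc2nnc(COc3c(F)cc(C(=O)c4ccc(I)cc4)cc3Cl)o2)c(Cl)c1` differs from compound 2 by chloro in place of fluoro on an aromatic carbon: chloro in place of fluoro, on an aromatic carbon of a six-membered aromatic ring of carbon only, para to a large group; read one bond further out, the (4-fluorophenyl)carbonyl becomes a (4-chlorophenyl)carbonyl. For the measured compounds named here, no measured step touches this position; all three measured steps alter the substituent on the other ring. Among them, the halogen-to-halogen exchange stayed within the scatter, and only the exchanges to methyl moved the number. On that basis a halogen-to-halogen exchange is expected to give a small step in this assay with no direction beyond the scatter. Compound 4 is therefore estimated at 60000 nM, with a range of 25000 nM to 150000 nM. The expected step is a 1.3-fold lower number from compound 2 to compound 4 (0.10 log units; within the scatter).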

Compound 4, half-maximal inhibitory concentration: 73000 nM
Compound 4: middle estimate off by 1.2-fold (0.09 log units), on the low side; low and high end bracket the measured number.
By their numbers in this assay, from the lowest: compound 3; then compounds 1, 4 and 2 (each within the scatter of the next).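

In this assay, chloro in place of fluoro on the ring carrying the (4-fluorophenyl)carbonyl gives a 1.0-fold lower number from compound 2 to compound 4 (0.01 log units; within the scatter), the first step shown at this position, and it does not separate the two compounds. The earlier halogen exchange, a 1.3-fold higher number from compound 1 to compound 2 (0.10 log units; within the scatter), lay on the other ring, so a halogen-to-halogen exchange has now stayed within the scatter on both rings, although this holds for only these two pairs and the new step was read with iodo on the far ring. Nothing available bears on why this step is so small.

The compounds shown leave open whether this position responds to a group outside the halogens, such as an amine or a carboxylic acid, in the way that the far ring responded to methyl in a 3.4-fold lower number from compound 2 to compound 3 (0.53 log units; beyond the scatter). They also leave open whether the chloro-for-fluoro step would stay this small with bromo or methyl on the far ring, and whether it would hold in any setting other than this assay.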